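A Second Chloro on Compound 2

The source may hold more compounds than are shown below. What is called first, only, known or untested is meant among the compounds shown, and "the series" means these compounds.

In a functional assay on NCI-H460 cells (Homo sapiens) for inhibition, read by sulforhodamine B assay, with a stated time of 48 h (a higher number here means a weaker inhibitor of growth, a lower number a stronger inhibitor of growth), compound 2 `CC(C)(C)NCc1c(C(=O)O)nn(-c2ccccc2)c1-c1ccc(Cl)cc1` is the only one of the three measured compounds with a true number, 70500 nM. Compound 1 `CC(C)(C)NCc1c(C(=O)O)nn(-c2ccccc2)c1-c1ccc(F)cc1` returns only a limit, > 680000 nM. Compound 3 `CC(C)(C)NCc1c(C(=O)O)nn(-c2ccccc2)c1-c1ccc([N+](=O)[O-])cc1` also returns only a limit, > 634000 nM. Compound 2 is the strongest inhibitor of growth of the three: an at least 9.6-fold lower number from compound 1 to compound 2 (0.98 log units; beyond the scatter), and an at least 8.9-fold higher number from compound 2 to compound 3 (0.95 log units; beyond the scatter), both beyond the scatter.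

Compound 4 `CC(C)(C)NCc1c(C(=O)O)nn(-c2ccc(Cl)cc2)c1-c1ccc(Cl)cc1` differs from compound 2 in one place: chloro in place of hydrogen on an aromatic carbon, phenyl to 4-chlorophenyl. Among the compounds with values here, no measured step makes this change, and all of them act on a different aromatic ring. The closest guide is compound 2 itself, where chloro entered in place of fluoro, giving an at least 9.6-fold lower number from compound 1 to compound 2 (0.98 log units; beyond the scatter). That step bears only loosely here, so a modest move to a lower number is expected in this assay, with no change beyond the scatter still possible. The expected change is a 1.8-fold lower number from compound 2 to compound 4 (0.25 log units; within the scatter). For compound 4 the estimated value is 40000 nM, with an expected range of 10000 nM to 160000 nM.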

Compound 4, concentration for 50% growth inhibition: > 599000 nM
Compound 4: a limit, no number; the forecaster's own chance of this, stated with the estimate: 15%; middle value at least 14-fold (1.17 log units) from the limit.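

In this assay, within the data shown here, the earlier compounds varied only the ring carrying fluoro, chloro or nitro, and compound 4 is the first to show that the phenyl ring also matters: chloro in place of hydrogen there gives an at least 8.4-fold higher number from compound 2 to compound 4 (0.92 log units; beyond the scatter) in the direction of weaker growth inhibition. Compound 4 returns only a limit, > 599000 nM, and no number, so how far this change weakens it cannot be told. Among these compounds, compound 2 therefore remains the only compound here with a true number, and a chloro that goes with that number on one ring does not bring a gain when added to the other.

As far as these compounds go, whether a methyl or a methoxy in this same place would read as chloro does remains open. From the compounds shown here alone, all four compounds keep the carboxylic acid, so how a primary amide in its place would read is also open.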